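The compounds below may be only part of what the source reports. "The series", "measured", "known", "first", "only" and "open" are said of these compounds alone.

Measured compounds in an ADME assay on microsomes from liver (Homo sapiens) for metabolic stability, read by HPLC, using NADPH, with stated times of 5 min and 60 min, tested at 10 uM; on this read-out higher numbers stand for fast clearance and lower numbers for slow clearance:
- compound 1 `CCS(=O)(=O)Nc1ccc(Oc2ccc(C(F)(F)F)cc2)c(-c2cn(C)c(=O)c3[nH]ccc23)c1`: 128 mL/min/kg
- compound 2 `Cn1cc(-c2cc(NS(C)(=O)=O)ccc2Oc2ccccc2C(F)(F)F)c2cc[nH]c2c1=O`: 533 mL/min/kg

Two compounds have been run so far. In this assay compound 2 gives 533 mL/min/kg, the higher of the two numbers, and compound 1 gives 128 mL/min/kg; the gap between them lies beyond the usual scatter of the method, so compound 2 is the faster-cleared of the pair on present evidence. The two differ in more than one place, and no single-point comparison between them is available.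

Compound 3 `Cn1cc(-c2cc(NS(C)(=O)=O)ccc2Oc2cccnc2)c2cc[nH]c2c1=O` has not yet been measured. It is drawn from compound 2 by a single change, (pyridin-3-yl in place of 2-(trifluoromethyl)phenyl on an oxygen on an aromatic ring). Among the compounds with values here, no measured pair in the set isolates this change, so the expectation for compound 3 rests only on where compound 2 stands. Compound 3 is expected to come out lower than compound 2 in this assay, with an estimated step of a 2.4-fold lower number from compound 2 to compound 3 (0.38 log units; beyond the scatter), a move that should exceed the scatter but remains uncertain in size. For compound 3 the estimate in this assay is 220 mL/min/kg, with a range from 90 mL/min/kg to 550 mL/min/kg.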

Compound 3, clearance: 86.7 mL/min/kg
Compound 3: middle estimate off by 2.5-fold (0.40 log units), on the high side; the whole stated range lies above it.
By their numbers in this assay, from the lowest: compounds 3 and 1 (each within the scatter of the next); then compound 2.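

Within the data shown here, replacing 2-(trifluoromethyl)phenyl with pyridin-3-yl on an oxygen on an aromatic ring gives, in this assay, a 6.1-fold lower number from compound 2 to compound 3 (0.79 log units; beyond the scatter), which is the first comparison that isolates a single place and shows that the group on this oxygen alone can move clearance beyond the scatter. The swap alters several things at once: the trifluoromethyl group leaves, the ring gains a nitrogen as its hetero atom, the hydrogen-bond acceptor count of the group rises, and the heavy-atom count of the group falls, so this single pair cannot assign the step to any one of them. Nothing available on these compounds bears on why clearance moves with this change.

As far as these compounds go, it remains open how much of the step follows the loss of the trifluoromethyl group and how much the arrival of the ring nitrogen; a plain phenyl on the same oxygen would separate the two. From the compounds shown here alone, it also remains open whether the same swap gives a step of similar size in the ethylsulfonyl series of compound 1, or whether a pyridin-4-yl group on this oxygen behaves like pyridin-3-yl.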